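The source may hold more compounds than are shown below. What is called first, only, known or untested is meant among the compounds shown, and "the series" means these compounds.

Measured compounds:
- compound 1, `Cn1c(=O)c(=O)n(C2CCCC2)c2nc(N/N=C/c3cccc(Cl)c3Cl)ncc21`: 17200 nM
- compound 2, `Cn1c(=O)c(=O)n(C2CCCC2)c2nc(N/N=C/c3cccs3)ncc21`: 75600 nM
- compound 3, `Cn1c(=O)c(=O)n(C2CCCC2)c2nc(N/N=C/c3cc(C(F)(F)F)cc(C(F)(F)F)c3)ncc21`: 8200 nM

These three compounds share one core and differ only in the aromatic group attached to the carbon with a double bond to nitrogen. In a functional assay on PC-3 cells (Homo sapiens) for antiproliferative activity, read by MTT assay (on this read-out higher numbers stand for weaker inhibition and lower numbers for stronger inhibition), compound 1 stands second highest of the three numbers: compound 3 gives 8200 nM, a lower number, while compound 2 gives 75600 nM, the highest. Within the data shown here, the one step between neighbours in this set is a 4.4-fold higher number from compound 1 to compound 2 (0.64 log units; beyond the scatter), which shows that exchanging the aromatic group on that carbon can move the number well beyond the scatter.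

Compound 4, `Cn1c(=O)c(=O)n(C2CCCC2)c2nc(N/N=C/c3ccccc3F)ncc21`, has not yet been measured in this assay. It differs from compound 1 by 2-fluorophenyl in place of 2,3-dichlorophenyl on a carbon with a double bond to nitrogen. Among the measured compounds shown here, no measured step exchanges one halogenated phenyl for another, so the direction is uncertain; the step from compound 1 to compound 2 shows that a smaller replacement at this carbon can weaken inhibition, while the values of compound 3 and compound 1 show that a more heavily substituted phenyl gave a lower number. A modest move toward a higher number, possibly within the scatter, is therefore expected: a 1.5-fold higher number from compound 1 to compound 4 (0.18 log units; within the scatter). Compound 4 is expected to give about 26000 nM, estimated between 10000 nM and 65000 nM.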

Compound 4, half-maximal inhibitory concentration: 27600 nM
Compound 4: middle estimate off by 1.1-fold (0.03 log units), on the low side; the measured number falls inside the stated range.
By their numbers in this assay, from the lowest: compound 3; then compounds 1 and 4 (each within the scatter of the next); then compound 2.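

In this assay, the exchange of 2,3-dichlorophenyl for 2-fluorophenyl gives a 1.6-fold higher number from compound 1 to compound 4 (0.21 log units; within the scatter) and so stays within the scatter: at this carbon, the assay does not separate these two halogenated phenyl groups, even though one carries two chlorine atoms and the other a single fluorine. The second step, a 2.7-fold lower number from compound 2 to compound 4 (0.44 log units; beyond the scatter) in the same assay, lies beyond the scatter, which shows that a phenyl ring with a single fluorine is already enough to separate the result from that of thiophen-2-yl, whereas the earlier step showed this only for the 2,3-dichlorophenyl group. The data shown offer no measurement that explains either step.

The compounds shown leave open what a plain phenyl ring without any halogen would give, so they cannot tell whether the halogen itself matters or whether the phenyl ring alone accounts for the difference from thiophen-2-yl. Going by these compounds, it also remains open how a pyridine ring, or a phenyl ring bearing a methoxy group or an amine, would read at this carbon.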